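The source may report more compounds than this note shows. Statements on the series, on what has been measured and on what is new or still open speak of the compounds shown alone.

Compounds and their values in an ADME assay on the whole organism with Oryza sativa as the target, tested at 0.1 uM; a lower number here means a stronger effect, a higher number a weaker effect of the compound at the concentration tested:
compound 1, `C[C@H](NC(=O)Nc1ccccc1C(C)(C)C)c1ccccc1`: 101%
compound 2, `COc1ccccc1NC(=O)N[C@@H](C)c1ccccc1`: 98%
compound 3, `C[C@H](NC(=O)Nc1ccccc1F)c1ccccc1`: 98%

Compound 3 sits level with compound 2, and together they hold the lowest of the three numbers; its nearest neighbour is compound 2, with no change at the digits printed from compound 2 to compound 3 (within the scatter), and its furthest is compound 1, with a number 3 percentage points lower from compound 1 to compound 3 (within the scatter). Compound 4, `C[C@H](NC(=O)Nc1cccc(F)c1F)c1ccccc1`, differs from compound 3 in one place: fluoro in place of hydrogen on an aromatic carbon. Going by the values given here, none of the measured steps adds a group; each swaps one group for another. Those steps were a number 3 percentage points lower from compound 1 to compound 2 (within the scatter), a number 3 percentage points lower from compound 1 to compound 3 (within the scatter) and no change at the digits printed from compound 2 to compound 3 (within the scatter), all within the scatter. On that basis no step beyond the scatter is expected for compound 4, and the expected step is no change at the digits printed from compound 3 to compound 4 (within the scatter). Compound 4 is therefore estimated at 98%, between 88% and 106%.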

Compound 4, a percentage reported as activity, at one concentration (the size of the read-out at that concentration, not a potency): 100%
Estimate against measurement, compound 4: 2 percentage points below; low and high end bracket the measured number.
By their numbers in this assay, from the lowest: compounds 2, 3, 4 and 1 (each within the scatter of the next).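

In this assay, placing a fluoro group on an aromatic carbon ortho to a fluoro group gives a number 2 percentage points higher from compound 3 to compound 4 (within the scatter), so this position takes a second fluoro with no step beyond the scatter. The earlier steps shown here each swapped one group for another, whereas this one puts a group where only a hydrogen stood, and the result again stays within the scatter. No available evidence bears on this result. As far as these compounds go, what an amine or a carboxylic acid on this carbon would do remains open, as does whether any group on this ring can move the number beyond the scatter.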